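Swapping the urea aryl on a quinazoline urea scaffold

The compounds below may be only part of what the source reports. "The series", "measured", "known", "first", "only" and "open" are said of these compounds alone.

Compound 1 `COc1cc(NC(=O)Nc2cccc3c(Nc4cc(OC)cc(OC)c4)ncnc23)cc(OC)c1` is the stronger of the two compounds measured in a functional assay on RT-112 cells (Homo sapiens) for antiproliferative activity, read by MTT assay, with a stated time of 72 h; a higher number here means a weaker inhibitor of growth, a lower number a stronger inhibitor of growth: compound 1 gives 366 nM, while compound 2 `COc1cc(Nc2ncnc3c(NC(=O)Nc4ccc(C)cc4C)cccc23)cc(OC)c1` gives 1290 nM, a step of a 3.5-fold higher number from compound 1 to compound 2 (0.55 log units; beyond the scatter). Compound 3 `COc1cc(Nc2ncnc3c(NC(=O)Nc4cccc(Cl)c4Cl)cccc23)cc(OC)c1` differs from compound 1 only on the same amide-type nitrogen: 2,3-dichlorophenyl in place of 3,5-dimethoxyphenyl on an amide-type nitrogen. Among the measured compounds shown here, the one relevant measured step, from compound 1 to compound 2, replaced the same group and weakened growth inhibition modestly, so a comparable step upward in this assay is expected. Compound 3 is therefore estimated at 1000 nM, within 350 nM to 3000 nM, an expected step of a 2.7-fold higher number from compound 1 to compound 3 (0.44 log units; beyond the scatter).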

Compound 3, concentration for 50% growth inhibition: 63.2 nM
The estimate for compound 3 lay 16-fold (1.20 log units) above the measured number; measured number below the stated range.
By their numbers in this assay, from the lowest: compound 3; then compound 1; then compound 2.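

In this assay, 2,3-dichlorophenyl on the amide-type nitrogen gives a 5.8-fold lower number from compound 1 to compound 3 (0.76 log units; beyond the scatter), so replacing 3,5-dimethoxyphenyl here can strengthen growth inhibition as well as weaken it. The two replacements also differ widely, with a 20-fold lower number from compound 2 to compound 3 (1.31 log units; beyond the scatter), so the outcome depends on which aryl group enters and not merely on the loss of 3,5-dimethoxyphenyl. Nothing available explains this difference.

The compounds shown leave open whether a phenyl ring with a single chlorine would retain this strength. They also leave open whether bromine or trifluoromethyl could stand in for the chlorines.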